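Exchanging an ester end for a hydroxyalkyl chain

This account rests on a few compounds, and the source may have more. Where it says the series, first, only, none or still open, it means among the compounds named here.

Measured compounds:
- compound 1, `CC(C)(C)c1ccc(C(=O)N2CCC3(CC2)C(=O)N(CC(=O)NCCC(=O)O)CN3c2ccccc2)cc1`: 11400 nM
- compound 2, `CC1(C)CC(OC(=O)CN2CN(c3ccccc3)C3(CCN(C(=O)c4ccc(C(C)(C)C)cc4)CC3)C2=O)CC(C)(C)N1`: 1300 nM
- compound 3, `COC(=O)CCNC(=O)CN1CN(c2ccccc2)C2(CCN(C(=O)c3ccc(C(C)(C)C)cc3)CC2)C1=O`: "not determined" (no result reported)

All three share one core and differ only in the group hanging from the amide-type nitrogen at the edge of that core. Within the data shown here, in an assay on HEK293 cells for displacement of a labelled ligand from NPC1-like intracellular cholesterol transporter 1 (Homo sapiens) (a lower number here means a stronger inhibitor, a higher number a weaker inhibitor), compound 1 gives 11400 nM, and compound 2 gives 1300 nM; the one measured step, an 8.8-fold lower number from compound 1 to compound 2 (0.94 log units; beyond the scatter), shows that altering this end group can move the number well beyond the scatter. Compound 3 carries a methyl ester at the chain end and has no number in this assay, so it stands only as a structural neighbour of compound 1.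

Compound 4, `CC(C)(C)c1ccc(C(=O)N2CCC3(CC2)C(=O)N(CC(=O)NCCCCCO)CN3c2ccccc2)cc1`, differs from compound 3 in one place: 3-hydroxypropyl in place of methoxycarbonyl on a saturated chain carbon, two bonds along the chain from an amide-type nitrogen. The ester becomes a plain hydroxyl-ended chain of the same length in heavy atoms. Among the measured compounds shown here, no measured step runs between an ester and a hydroxyalkyl end, and the step from compound 1 to compound 2 involves a different exchange, so it gives only a loose sense of how much this position can matter. With compound 1 as the nearest measured anchor, compound 4 is expected to land near it, most likely somewhat lower, at roughly 6000 nM with a range from 1500 nM to 25000 nM.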

Compound 4, half-maximal inhibitory concentration: 9400 nM
Compound 4: the middle estimate sits 1.6-fold (0.19 log units) below what was measured; the range from low to high includes it.
By their numbers in this assay, from the lowest: compound 2; then compounds 4 and 1 (each within the scatter of the next).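

In this assay, a 1.2-fold lower number from compound 1 to compound 4 (0.08 log units; within the scatter) is a step within the scatter, so at this position the 3-hydroxypropyl end and the carboxy end cannot be told apart, even though the carboxy group is the one that leaves. The other new step, a 7.2-fold higher number from compound 2 to compound 4 (0.86 log units; beyond the scatter), lies beyond the scatter, and compound 2 now differs beyond the scatter from two measured compounds with quite different chain ends, not just one. The exchange of methoxycarbonyl for 3-hydroxypropyl itself cannot be read, with no number for compound 3 at its starting end.

Compound 2 differs from the other two in both its ring-bearing end and the oxygen that links that end to the carbonyl, so the shown compounds do not separate these two features, and a (2,2,6,6-tetramethylpiperidin-4-yl)amino end or a chain ending in a plain amine on the same amide would be needed to do that. No measurement shown here explains why any of these numbers stands where it does.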